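The source may hold more compounds than are shown below. What is called first, only, known or untested is meant among the compounds shown, and "the series" means these compounds.

In a functional assay on MCF7 cells (Homo sapiens) for antiproliferative activity, with a stated time of 5 days (a lower number here means a stronger inhibitor, a higher number a weaker inhibitor), compound 1 (`COc1ccc(-c2[nH]c3ccc(OC)cc3c2C=C(C#N)C#N)cc1`) gives 340 nM and compound 2 (`COc1ccc(-c2[nH]c3ccc(C)cc3c2C=C(C#N)C#N)cc1`) gives 200 nM as its reading. These two numbers lie within the scatter of each other, so compound 2 cannot be ranked against compound 1 on these data. Compound 3 (`CCCc1ccc2[nH]c(-c3ccc(OC)cc3)c(C=C(C#N)C#N)c2c1`) has not yet been measured. In it the methyl of compound 2 becomes a propyl, which means ethyl in place of hydrogen on a saturated chain carbon bound to an aromatic carbon. For the measured compounds named here, only one measured step bears on this change: replacing methoxy with methyl at the same substituent gave a 1.7-fold lower number from compound 1 to compound 2 (0.23 log units; within the scatter) as its size. Going by the values given here, no measured compound carries a longer chain, so this evidence is thin and says nothing direct about chain length. Going by that small step, no change beyond the scatter is expected in this assay in either direction. The estimate amounts to a 1.2-fold higher number from compound 2 to compound 3 (0.06 log units; within the scatter) as the expected step. For compound 3 the estimate is 230 nM with an expected range from 80 nM to 650 nM as its span.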

Compound 3, half-maximal inhibitory concentration: 190 nM
Beside the measured number, compound 3's estimate is 1.2-fold (0.08 log units) above it, within the range that was stated.
By their numbers in this assay, from the lowest: compounds 3, 2 and 1 (each within the scatter of the next).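

For the compounds shown here, at this place, on a saturated chain carbon bound to an aromatic carbon, compound 3 gives the first reading on chain length: in this assay, ethyl in place of hydrogen gives a 1.1-fold lower number from compound 2 to compound 3 (0.02 log units; within the scatter) and so cannot be told apart from the methyl of compound 2. Set against the methoxy group of compound 1, the propyl group gives a 1.8-fold lower number from compound 1 to compound 3 (0.25 log units; within the scatter) in this assay, so methoxy, methyl and propyl cannot be ranked against one another at this position on these data. No accompanying evidence bears on this result.

Still open, as far as these compounds go, is whether a longer chain such as hexyl, a branched chain such as isopropyl, or a chain ending in an amine or a carboxylic acid would remain within the scatter of these readings. Equally open, from the compounds shown here alone, is whether a ring at this place, such as cyclohexyl or phenyl, would leave the reading in this assay where the three chains and the methoxy group have put it so far.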